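The compounds below may be only part of what the source reports. "The series", "measured", "known", "first", "only" and "open" are said of these compounds alone.

Measured in a functional assay on CCRF-SB cells (Homo sapiens); on this read-out higher numbers stand for weaker inhibition and lower numbers for stronger inhibition:
- Compound 1 `O=C(O)c1nn([C@@H]2O[C@H](CO)[C@@H](O)[C@H]2O)cc1I`: > 300000 nM (a limit of the assay, not a number)
- Compound 2 `CCCCOC(=O)c1nn([C@@H]2O[C@H](CO)[C@@H](O)[C@H]2O)cc1I`: 21000 nM

For the measured compounds named here, compound 2 holds the only true number so far. Compound 3 `Cc1noc(-c2nn([C@@H]3O[C@H](CO)[C@@H](O)[C@H]3O)cc2I)n1` has 3-methyl-1,2,4-oxadiazol-5-yl in place of butoxycarbonyl on an aromatic carbon. Going by the values given here, the one measured step bearing on this is large: an at least 14-fold lower number from compound 1 to compound 2 (1.15 log units; beyond the scatter). As far as these compounds go, it starts from the limit of > 300000 nM in this assay, at which 1 of the 2 values shown sits, so its full size is unknown. It shows that this group can matter, but it does not test a swap of the whole group. The expected change in this assay is small and leans towards weaker inhibition: a 1.7-fold higher number from compound 2 to compound 3 (0.22 log units; within the scatter). For compound 3 the estimate is 35000 nM, with an expected range of 8000 nM to 150000 nM.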

Compound 3, half-maximal inhibitory concentration: 2800 nM
Compound 3: the middle estimate sits 13-fold (1.10 log units) above what was measured; the measured number lies below the stated range.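

In this assay, butoxycarbonyl is not the best group shown on this aromatic carbon: 3-methyl-1,2,4-oxadiazol-5-yl gives a 7.5-fold lower number from compound 2 to compound 3 (0.88 log units; beyond the scatter). A ring can therefore take the place of the open chain, and inhibition still gets stronger. Against carboxy the change is an at least 100-fold lower number from compound 1 to compound 3 (2.02 log units; beyond the scatter), but this gives only a minimum size, since compound 1 rests on a limit and not a number: the limit of > 300000 nM in this assay, at which 1 of the 3 values shown sits.

As far as these compounds go, it remains open whether the ring alone or its methyl carries this change. A 3-ethyl-1,2,4-oxadiazol-5-yl group or a simple amide at this place would help separate the two.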